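Acetylation of a hydrazone nitrogen in two selenazole series

The compounds below may be only part of what the source reports. "The series", "measured", "known", "first", "only" and "open" are said of these compounds alone.

The measured compounds and their values in a functional assay on HepG2 cells (Homo sapiens) for cytotoxicity, read by XTT assay, with a stated time of 72 h (a higher number here means a weaker inhibitor, a lower number a stronger inhibitor), are:

Compound 1, `ClCc1c[se]c(N/N=C/c2csc(-c3ccccc3)n2)n1`: 18800 nM
Compound 2, `CC(=O)c1[se]c(N/N=C/c2csc(-c3ccccc3)n2)nc1C`: 61300 nM
Compound 3, `CC(=O)N(/N=C/c1csc(-c2ccccc2)n1)c1nc(CCl)c[se]1`: 19300 nM

Compound 3 is obtained from compound 1 by the change (acetyl in place of hydrogen on a nitrogen on an aromatic ring). The step this made in this assay was a 1.0-fold higher number from compound 1 to compound 3 (0.01 log units; within the scatter), so compound 1 and compound 3 sit within the scatter of each other and no order between them can be claimed. Compound 2 carries a different core; how the core of compound 2 differs from the core of compound 1 is not broken down here. In this assay compound 2 stands at the highest number of the three, beyond the scatter from both compound 1 and compound 3.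

Compound 4, `CC(=O)c1[se]c(N(/N=C/c2csc(-c3ccccc3)n2)C(C)=O)nc1C`, has not yet been measured. It is obtained from compound 2 by the change (acetyl in place of hydrogen on a nitrogen on an aromatic ring). Within the data shown here, this is the same change as the one from compound 1 to compound 3, made at the same kind of place on a different core. Among the measured compounds shown here, since the earlier step was a 1.0-fold higher number from compound 1 to compound 3 (0.01 log units; within the scatter), the step from compound 2 to compound 4 is expected to be of similar size, that is a 1.0-fold lower number from compound 2 to compound 4 (0.01 log units; within the scatter), because compound 2 gives 61300 nM and the only comparable step made no difference beyond the scatter. Compound 4 is therefore estimated at 60000 nM, within a range from 30000 nM to 120000 nM.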

Compound 4, half-maximal inhibitory concentration: 29400 nM
The estimate for compound 4 lay 2.0-fold (0.31 log units) above the measured number, and the stated range ends above it.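

In this assay, putting acetyl in place of hydrogen on the nitrogen gave a 2.1-fold lower number from compound 2 to compound 4 (0.32 log units; beyond the scatter), a modest step on the core of compound 2. Set beside the earlier step, this result gives no firm sign that the change behaves differently on the two cores, even though only one of the two steps lies beyond the scatter: the same change on two cores in this assay, a 1.0-fold higher number (0.01 log units; within the scatter) from compound 1 to compound 3 and a 2.1-fold lower number (0.32 log units; beyond the scatter) from compound 2 to compound 4, 2.1-fold (0.33 log units) apart, within the scatter of two such steps. Among these compounds, this shows that the change carried from one core to the other without a distinguishable difference in step size, but with only two pairs it does not show that the step is the same on both cores, that it would hold on any further core, or that acetylation reliably lowers the number.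

The compounds shown leave open whether a longer acyl chain such as butanoyl, or a methyl group, on the same nitrogen would give a step like that of acetyl. They also leave open how the change would behave on a core carrying an amine or a carboxylic acid in place of the chloromethyl group of compound 1 or the acetyl group of compound 2.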